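A few compounds are considered here, and "the series" means these few. Any claim that something is new, unique, unknown or untested is made for them only; others in the source may bear on it.

Of the compounds shown here, two sharing one core have been tested so far in a functional assay on HCT-116 cells (Homo sapiens) for antiproliferative activity, read by MTT assay, with a stated time of 24 h; a lower number here means a stronger inhibitor, a higher number a weaker inhibitor. Compound 1 `COc1ccc(/C=C/C(=O)c2ccc(OC)c3c2OC(C)(C)C=C3)cn1` gives > 10000 nM, which is a limit and not a number. Compound 2 `COc1ccccc1/C=C/C(=O)c1ccc(OC)c2c1OC(C)(C)C=C2` gives > 10000 nM, which is also a limit. Compound 2 therefore has no exact value of its own. Compound 3 `COc1ccc(C(=O)/C=C/c2cc(Cl)ccc2O)c2c1C=CC(C)(C)O2` differs from it in one group: 5-chloro-2-hydroxyphenyl in place of 2-methoxyphenyl on a double-bonded chain carbon bound to a double-bonded chain carbon. The 5-chloro-2-hydroxyphenyl takes the place of 2-methoxyphenyl on a double-bonded chain carbon bound to a double-bonded chain carbon. Within the data shown here, the only measured change at this place is a step that the two limits leave unreadable from compound 1 to compound 2, so no size can be carried over from it. Because the limit of > 10000 nM in this assay, at which 2 of the 2 values shown sit, the data offer no sign of a large gain, and no clear step beyond the scatter is expected. The expected step is an at least 1.1-fold lower number from compound 2 to compound 3 (0.04 log units; that floor lies within the scatter). For compound 3 the estimate is 9000 nM, with an expected range from 2500 nM to 30000 nM.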

Compound 3, half-maximal inhibitory concentration: 5240 nM
Estimate against measurement, compound 3: 1.7-fold (0.23 log units) above, and the stated range covers the measured number.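

Of the three compounds shown, only compound 3 gives an exact number in this assay, so this position on the chain can hold a group that brings the reading under the limit of the assay. Putting 5-chloro-2-hydroxyphenyl here gives an at least 1.9-fold lower number from compound 2 to compound 3 (0.28 log units; that floor lies within the scatter), and against the other partner it gives an at least 1.9-fold lower number from compound 1 to compound 3 (0.28 log units; that floor lies within the scatter). Both steps are floors and not true sizes, because neither partner of compound 3 has an exact value of its own: the limit of > 10000 nM in this assay, at which 2 of the 3 values shown sit.

The new group differs from 2-methoxyphenyl in both its chlorine and its hydroxyl, and the compounds shown do not separate these two changes. From the compounds shown here alone, how a plain 2-hydroxyphenyl, or a ring carrying an amine or a carboxylic acid, would read at this place remains open.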